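This account rests on a few compounds, and the source may have more. Where it says the series, first, only, none or still open, it means among the compounds named here.

Working notes on the urea series, step from compound 2 to compound 4.

Of the compounds shown here, three of the shared core have been measured in a functional assay on NCI-H520 cells (Homo sapiens) for inhibition, read by MTT assay, with a stated time of 48 h, tested at 10 uM; a lower number here means less inhibition, a higher number more inhibition at the concentration tested (going by the name of the read-out). Compound 1 `COc1ccc(F)cc1Nc1cc(NC(=O)Nc2c(Cl)cccc2Cl)ncn1` gives 38.1%. Compound 2 `COc1cc(NC(=O)Nc2cc(Nc3ccc(C)c(C)c3)ncn2)cc(OC)c1` gives 29.5%. Compound 3 `COc1ccc(Nc2cc(NC(=O)Nc3c(Cl)cccc3Cl)ncn2)cc1C` gives 29.1%. Compound 2 stands second highest of the three numbers; its nearest neighbour is compound 3, and its furthest is compound 1, both within the scatter, so no order among the three can be claimed.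

Compound 4 `COc1cc(NC(=O)Nc2cc(Nc3cc(I)ccc3OC)ncn2)cc(OC)c1` is not yet measured. It differs from compound 2 in one place: 5-iodo-2-methoxyphenyl in place of 3,4-dimethylphenyl on a nitrogen on an aromatic ring

Going by the values given here, one measured step touches the same position, the aryl group on the nitrogen on the aromatic ring: a number 9 percentage points lower from compound 1 to compound 3 (within the scatter). That step also carries the 2-methoxyphenyl pattern that enters in compound 4, with a fluorine where compound 4 carries iodine, and it stayed within the scatter. Among the compounds with values here, no measured step carries iodine. On this basis the change from compound 2 to compound 4 is expected to give no step beyond the scatter in this assay, with the estimated step of a number 3.5 percentage points higher from compound 2 to compound 4 (within the scatter) centred near the spread of the three measured numbers.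

Compound 4 is therefore expected to give 33% in this assay, with a range from 19% to 47%.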

Compound 4, a percentage reported as inhibition, at one concentration (the size of the read-out at that concentration, not a potency): 55%
Compound 4: middle estimate off by 22 percentage points, on the low side; the whole stated range lies below it.
By their numbers in this assay, from the lowest: compounds 3, 2 and 1 (each within the scatter of the next); then compound 4.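

In the work on this position, measured in this assay, the aryl group on a nitrogen on an aromatic ring proves able to move the read-out beyond the scatter, with 5-iodo-2-methoxyphenyl in place of 3,4-dimethylphenyl (a number 25.5 percentage points higher from compound 2 to compound 4 (beyond the scatter)). Going by these compounds alone, the earlier step at this position (a number 9 percentage points lower from compound 1 to compound 3 (within the scatter)) stayed within the scatter, so the earlier compounds gave no sign of a change of this size, and the new step holds only for the urea partner shared by compound 2 and compound 4. Nothing at hand accounts for the size of this step.

The step exchanges the whole aryl group, so the part played by the iodine cannot be separated from that of the methoxy group; a 2-methoxyphenyl group without iodine, or with bromine or chlorine in place of the iodine, on the same urea partner would divide the step. Also open, from the compounds shown here alone, is whether 5-iodo-2-methoxyphenyl gives a step of this size with the urea partner of compound 1, and, as the read-out comes from one concentration, how the step relates to potency.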